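Compound 3 to compound 4: beyond the measured steps

A few compounds are considered here, and "the series" means these few. Any claim that something is new, unique, unknown or untested is made for them only; others in the source may bear on it.

Three compounds share one core and differ in a single substituent. In a functional assay on the whole organism with Rattus norvegicus as the target (a higher number here means that more compound is needed for the effect, a lower number that less compound is needed), compound 1 `CCOCCOC(=O)C(=O)Nc1nc(-c2cc(Br)no2)cs1` gives > 30 mg/kg, which is a limit and not a number. Compound 2 `CCOCCOC(=O)C(=O)Nc1nc(-c2cc(OC)no2)cs1` gives 11 mg/kg. Among the compounds with values here, compound 3 `CCOCCOC(=O)C(=O)Nc1nc(-c2cc(COC)no2)cs1` gives 0.7 mg/kg, the lowest number so far. Its nearest neighbour lies at a 16-fold lower number from compound 2 to compound 3 (1.20 log units; beyond the scatter), and the gap from the limit is an at least 42-fold lower number from compound 1 to compound 3 (1.63 log units; beyond the scatter).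

Compound 4 `CCOCCOC(=O)C(=O)Nc1nc(-c2conc2C)cs1` carries 3-methyl-1,2-oxazol-4-yl in place of 3-(methoxymethyl)-1,2-oxazol-5-yl on an aromatic carbon of the shared core (3-methyl-1,2-oxazol-4-yl in place of 3-(methoxymethyl)-1,2-oxazol-5-yl on an aromatic carbon). Within the data shown here, both the substituent and the point of attachment of the group change, and no measured step covers either change directly. The closest evidence is the substituent swaps, which gave an at least 2.7-fold lower number from compound 1 to compound 2 (0.43 log units; beyond the scatter) and a 16-fold lower number from compound 2 to compound 3 (1.20 log units; beyond the scatter). These show that this assay can respond strongly to a single replacement in this group. Methoxymethyl in compound 3 gives the best reading of the three, so losing it points upward, and the unmeasured change of attachment widens the uncertainty. The expected change is a 7.1-fold higher number from compound 3 to compound 4 (0.85 log units; beyond the scatter), a large but poorly bounded estimate. In this assay, compound 4 is estimated at 5 mg/kg, with an expected range of 0.9 mg/kg to 28 mg/kg.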

Compound 4, dose for half-maximal effect: > 100 mg/kg
Compound 4: no number, only a limit; the forecaster's own chance of this, stated with the estimate: 20%; middle value at least 20-fold (1.30 log units) away from the limit.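

The reading for compound 4 is a limit of the assay and not a number: the limit of > 100 mg/kg in this assay, at which 1 of the 4 values shown sits. In this assay, within the data shown here, the earlier compounds varied only the substituent on a 1,2-oxazol-5-yl group, whereas 3-methyl-1,2-oxazol-4-yl changes the substituent and the attachment together, and it gives an at least 140-fold higher number from compound 3 to compound 4 (2.15 log units; beyond the scatter) and an at least 9.0-fold higher number from compound 2 to compound 4 (0.95 log units; beyond the scatter), so this combined change moves the number up from both compounds that have one. Compound 1 also stands at a limit of the assay, and its step to compound 4 cannot be read: the limit of > 30 mg/kg in this assay, at which 1 of the 4 values shown sits.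

The compounds shown do not separate the loss of methoxymethyl from the change of attachment, and a methyl group on the 1,2-oxazol-5-yl attachment, or methoxymethyl on the 1,2-oxazol-4-yl attachment, would each differ from compound 3 in one place. Also open, on these data alone, is how far the low number of compound 3 in this assay depends on methoxymethyl itself, for which a longer chain such as ethoxymethyl, or an amine such as aminomethyl, would be the direct comparison.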